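This account rests on a few compounds, and the source may have more. Where it says the series, first, only, none or still open, it means among the compounds named here.

Compound 2, `Cc1nnc(SCC(=O)c2ccccc2)n1N1C(=O)c2ccccc2C1=O`, was tested in a functional assay on A549 cells (Homo sapiens) for cytotoxicity, read by MTT assay, with a stated time of 48 h (on this read-out higher numbers stand for weaker inhibition and lower numbers for stronger inhibition), and gave only a limit of the assay, > 200000 nM. Compound 1, `Cc1nnc(SCC(=O)c2ccc(Cl)cc2)n1N1C(=O)c2ccccc2C1=O`, likewise reached only a limit in this assay, > 200000 nM. Compound 3, `CSc1nnc(C)n1N1C(=O)c2ccccc2C1=O`, also gave only a limit in this assay, > 200000 nM. Thus every value so far sits at the same limit, and the three steps that connect these compounds cannot be sized: a step that the two limits leave unreadable from compound 1 to compound 2, a step that the two limits leave unreadable from compound 1 to compound 3 and a step that the two limits leave unreadable from compound 2 to compound 3 are all unreadable due to the limit of > 200000 nM in this assay, at which 3 of the 3 values shown sit. Compound 2 therefore stands at the edge of what this assay can report, level with the other two compounds as far as the numbers show.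

Compound 4, `COc1cc(-c2nnc(SCC(=O)c3ccccc3)n2N2C(=O)c3ccccc3C2=O)cc(OC)c1OC`, differs from compound 2 in one place: 3,4,5-trimethoxyphenyl in place of methyl on an aromatic carbon. Among the compounds with values here, none of the measured steps touches this position of the shared core, and none of them yields a readable size, so nothing in the data indicates a direction or size for the step in this assay. The expected value for compound 4 is 120000 nM, with a range from 20000 nM to 700000 nM. The step from compound 2 to compound 4 is accordingly expected to be an at least 1.6-fold lower number from compound 2 to compound 4 (0.22 log units; that floor lies within the scatter), with a considerable chance that this assay again reports only a limit for compound 4.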

Compound 4, half-maximal inhibitory concentration: > 200000 nM
Compound 4: a limit, no number; the forecaster's own chance of this, stated with the estimate: 55%; middle value at least 1.6-fold (0.22 log units) from the limit.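

In this assay compound 4 gives > 200000 nM, which is a limit and not a number. The step between compound 2 and compound 4 therefore cannot be read, because both values are limits: the limit of > 200000 nM in this assay, at which 4 of the 4 values shown sit.

The compounds shown leave open whether any of these changes moves the read-out at all, and in which direction.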